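The source may hold more compounds than are shown below. What is called first, only, known or untested is meant among the compounds shown, and "the series" means these compounds.

Compound 3 `COc1ccc(/C=C/C(=O)c2cccc(-n3cc(C(C)(C)O)nn3)c2)cc1O` gives 17100 nM in a functional assay on RAW264.7 cells (Mus musculus) for inhibition, with a stated time of 4 days; on this read-out lower numbers stand for stronger inhibition and higher numbers for weaker inhibition. Compound 1 `COc1cc(/C=C/C(=O)c2cccc(-n3cc(C(C)(C)O)nn3)c2)ccc1O` gives 19800 nM and compound 2 `COc1cc(/C=C/C(=O)c2cccc(-n3cc(-c4cc(F)cc(F)c4)nn3)c2)ccc1O` gives 22800 nM in this assay, so compound 3 holds the lowest of the three numbers, though a 1.2-fold lower number from compound 1 to compound 3 (0.06 log units; within the scatter) shows it sits within the scatter of compound 1, and the gap to compound 2 is also within it. Compound 4 `COc1ccc(/C=C/C(=O)c2cccc(-n3cc(-c4ccc(Br)cc4)nn3)c2)cc1O` differs from compound 3 by 4-bromophenyl in place of 1-hydroxy-1-methylethyl on an aromatic carbon. Within the data shown here, the one measured step that bears on this exchange saw a 1.2-fold higher number from compound 1 to compound 2 (0.06 log units; within the scatter) when a 3,5-difluorophenyl replaced the 1-hydroxy-1-methylethyl on an aromatic carbon of the shared core. A similarly small step is therefore expected, a 1.1-fold higher number from compound 3 to compound 4 (0.02 log units; within the scatter), with no movement beyond the scatter. Compound 4 is estimated at 18000 nM, between 9000 nM and 36000 nM.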

Compound 4, half-maximal inhibitory concentration: 6570 nM
Compound 4: middle estimate off by 2.7-fold (0.44 log units), on the high side; the whole stated range lies above it.
By their numbers in this assay, from the lowest: compound 4; then compounds 3, 1 and 2 (each within the scatter of the next).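

In this assay, among these compounds, this carbon of the triazole-type ring turns out to matter: 4-bromophenyl in place of 1-hydroxy-1-methylethyl gives a 2.6-fold lower number from compound 3 to compound 4 (0.42 log units; beyond the scatter) and is the first change to pass the scatter. On the core of compound 1, 3,5-difluorophenyl in the same place gave only a 1.2-fold higher number from compound 1 to compound 2 (0.06 log units; within the scatter) and so an added aromatic ring does not always lower the number. Nothing available explains this difference. Still open, as far as these compounds go, is whether 4-bromophenyl would act alike on the core of compound 1, and whether an amine or a carboxylic acid on that ring would keep the gain.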